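Oxolane-methyl chain replaces pentan-3-yl: expected cytotoxicity outcome

A few compounds are considered here, and "the series" means these few. Any claim that something is new, unique, unknown or untested is made for them only; others in the source may bear on it.

Compound 1 `CCC(CC)Nc1cc(Oc2c(OC)cc3cc(C#N)ccc3c2OC)nc(Nc2ccc(C#N)cc2)n1` is read in an ADME assay on MT4 cells (Homo sapiens) for cytotoxicity, read by MTT assay, with a stated time of 5 days (on this read-out lower numbers stand for higher toxicity in this test and higher numbers for lower toxicity in this test), only as a limit, > 125000 nM. Compound 2 `COc1cc2cc(C#N)ccc2c(OC)c1Oc1cc(NC2CCOC2)nc(Nc2ccc(C#N)cc2)n1` likewise reaches only a limit, > 125000 nM. Both values sit at the limit of > 125000 nM in this assay, at which 2 of the 2 values shown sit, so the step that the two limits leave unreadable from compound 1 to compound 2 cannot be sized. Compound 3 `COc1cc2cc(C#N)ccc2c(OC)c1Oc1cc(NCC2CCOC2)nc(Nc2ccc(C#N)cc2)n1` differs from compound 1 by (oxolan-3-yl)methyl in place of pentan-3-yl on a nitrogen on an aromatic ring. Going by the values given here, the one measured step that resembles this change is unreadable, so no shift beyond the scatter is expected, and the step that the limit leaves unreadable from compound 1 to compound 3 is expected to be small. Compound 3 is therefore estimated at 150000 nM, with a range from 60000 nM to 400000 nM, most likely again reported only as a limit.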

Compound 3, half-maximal cytotoxic concentration: > 125000 nM
Compound 3: no number, only a limit; the forecaster's own chance of this, stated with the estimate: 85%; the middle value is on the limit's open side.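

Going by these compounds alone, no step among compound 1, compound 2 and compound 3 can be read, because all three give no number and stop at the same limit: the limit of > 125000 nM in this assay, at which 3 of the 3 values shown sit.

On these data alone, how far these compounds lie apart in this assay stays open.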